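A halogen swap on the sulfonyl sulfur

The source may report more compounds than this note shows. Statements on the series, on what has been measured and on what is new or still open speak of the compounds shown alone.

Two measured compounds set the scene. Compound 1 `O=C(O)CCC/C=C\CC1=CCC[C@@H]1NS(=O)(=O)c1cccc2cccnc12` was tested in a functional assay on a cell-free system (plasma) for inhibition of thromboxane A2 receptor (Homo sapiens), read by turbidimetry (on this read-out higher numbers stand for weaker inhibition and lower numbers for stronger inhibition), and gives 2000 nM. Compound 2 `O=C(O)COCCCCC1=CCC[C@@H]1NS(=O)(=O)c1ccc(Cl)c(Cl)c1` in this assay gives 1900 nM, a number that lies within the scatter of that of compound 1, so the two cannot be told apart on these data. Among the compounds with values here, no pair differing in only one place has been measured, so no step size is yet known from experiment.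

Compound 3 `O=C(O)COCCCCC1=CCC[C@@H]1NS(=O)(=O)c1ccc(F)cc1F` differs from compound 2 in one place: 2,4-difluorophenyl in place of 3,4-dichlorophenyl on a sulfonyl sulfur. Within the data shown here, no measured pair shows what this change does. The expectation for the step from compound 2 to compound 3 in this assay is therefore a 1.3-fold higher number from compound 2 to compound 3 (0.12 log units; within the scatter), that is, no change beyond the scatter. Compound 3 is estimated to give 2500 nM in this assay, with a range from 800 nM to 8000 nM.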

Compound 3, half-maximal inhibitory concentration: 1800 nM
Compound 3: middle estimate off by 1.4-fold (0.14 log units), on the high side; low and high end bracket the measured number.
By their numbers in this assay, from the lowest: compounds 3, 2 and 1 (each within the scatter of the next).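

In this assay, within the data shown here, the exchange of 3,4-dichlorophenyl for 2,4-difluorophenyl on a sulfonyl sulfur gives a 1.1-fold lower number from compound 2 to compound 3 (0.02 log units; within the scatter) and is the first single-place step known for this series. At this position, then, two aryl groups with different halogens, differently placed on the ring, cannot be told apart on this read-out, so this place tolerates this particular exchange without a change beyond the scatter. Nothing available bears on why the two groups read alike.

On these data alone, the step alters the halogen and its placement together, so the contribution of each remains unknown. Also open, as far as these compounds go, is whether a larger change on the sulfonyl sulfur, such as an unsubstituted phenyl or a phenyl carrying an amine or a carboxylic acid, would move the number beyond the scatter.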